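The compounds below may be only part of what the source reports. "The series", "measured", "known", "first", "only" and "open" are said of these compounds alone.

In a functional assay on HFF cells (Homo sapiens) for cytotoxicity (on this read-out higher numbers stand for weaker inhibition and lower numbers for stronger inhibition), two compounds of this set have been measured so far. Compound 1 `CCCCOC[C@H]1O[C@@H](n2c(Cl)nc3cc(Cl)c(Cl)cc32)[C@H](OC(C)=O)[C@@H]1OC(C)=O` gives 66000 nM. Compound 2 `CC(=O)OC1C(CBr)OC(n2c(Cl)nc3cc(Cl)c(Cl)cc32)C1OC(C)=O` gives 32000 nM, the lower of the two numbers, and its gap to compound 1 lies beyond the usual scatter, though only just. Compound 3 `CSCC1OC(n2c(Cl)nc3cc(Cl)c(Cl)cc32)C(OC(C)=O)C1OC(C)=O` has not yet been measured. It carries methylsulfanyl in place of bromo on a saturated chain carbon bound to a saturated ring carbon. Among the compounds with values here, no two measured compounds differ in one place only, so no measured step bears directly on this change. Within the data shown here, the only guide is compound 1 at 66000 nM, which also has no bromo, so a modest rise in this assay is expected, towards weaker inhibition. The expected size of this change is a 1.6-fold higher number from compound 2 to compound 3 (0.19 log units; within the scatter). For compound 3 the estimated value is 50000 nM, with an expected range of 20000 nM to 110000 nM.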

Compound 3, half-maximal inhibitory concentration: 32000 nM
For compound 3 the middle estimate is 1.6-fold (0.19 log units) above the measured one; measured number inside the range.
By their numbers in this assay, from the lowest: compounds 2 and 3 (each within the scatter of the next); then compound 1.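

In this assay, within the data shown here, methylsulfanyl in place of bromo on a saturated chain carbon bound to a saturated ring carbon gives no change at the digits printed from compound 2 to compound 3 (within the scatter), the first one-place step in this set and so the first direct reading at this position. For this pair, the bromo is not needed to keep the number of compound 2, since compound 3 carries a sulfur group there and no bromine. No evidence is at hand that bears on why the two groups read alike.

What the compounds shown leave open is whether this flat reading extends to other groups at the same place, such as an amine, a carboxylic acid or a longer alkylsulfanyl chain. As far as these compounds go, it also remains open whether the step would read the same with free hydroxyl groups in place of the acetates on the shared core.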